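The compounds below may be only part of what the source reports. "The series", "measured", "known", "first", "only" and "open" are said of these compounds alone.

In an ADME assay on HeLa cells (Homo sapiens) for cytotoxicity, read by MTT assay, with a stated time of 72 h (a higher number here means a weaker inhibitor of growth, a lower number a stronger inhibitor of growth), compound 1 `O=C(/C=C\c1ccccc1O)N1N=C(c2ccncc2)OC1c1c[nH]c2ccccc12` gives 26.8 ug/mL. Compound 2 `O=C(/C=C\c1cccc([N+](=O)[O-])c1)N1N=C(c2ccncc2)OC1c1c[nH]c2ccccc12` reaches only the limit of the measurement, > 30 ug/mL. Compound 3 `O=C(/C=C\c1ccc([N+](=O)[O-])cc1)N1N=C(c2ccncc2)OC1c1c[nH]c2ccccc12` likewise stops at a limit, > 30 ug/mL, so where it stands is known only as weak. The change to compound 4 `Cc1ccc(/C=C\C(=O)N2N=C(c3ccncc3)OC2c2c[nH]c3ccccc23)cc1` is methyl in place of nitro on an aromatic carbon. The measured steps that bear on it alter the same ring: an at least 1.1-fold higher number from compound 1 to compound 2 (0.04 log units; that floor lies within the scatter) and an at least 1.1-fold higher number from compound 1 to compound 3 (0.04 log units; that floor lies within the scatter), both with floors within the scatter, while a step that the two limits leave unreadable from compound 2 to compound 3. Given (the limit of > 30 ug/mL in this assay, at which 2 of the 3 values shown sit), no change on this ring has yet produced a readable number, so in this assay no step beyond the scatter is expected for compound 4, and a further limit is the most likely outcome. Compound 4 is therefore expected at 32 ug/mL, between 14 ug/mL and 70 ug/mL, which means an expected step that the limit leaves unreadable from compound 3 to compound 4.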

Compound 4, concentration for 50% growth inhibition: > 30 ug/mL
Compound 4 gave a limit, no number; the forecaster's own chance of this, stated with the estimate: 60%; the middle value does not contradict the limit.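

In this assay, compound 4 puts methyl, a single carbon with no hydrogen-bond acceptors, where compound 3 carries nitro, and its result is again a limit rather than a number. Among these compounds, the steps from compound 2 and compound 3 to compound 4 cannot be read, and the only readable step is an at least 1.1-fold higher number from compound 1 to compound 4 (0.04 log units; that floor lies within the scatter). Swapping nitro for methyl on this ring therefore yields no measured number, and the limit now covers most of the series: the limit of > 30 ug/mL in this assay, at which 3 of the 4 values shown sit.

As far as these compounds go, how compound 2, compound 3 and compound 4 rank against each other stays open. From the compounds shown here alone, whether an amine or a carboxylic acid at this place would give a number also stays open.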